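The compounds below may be only part of what the source reports. "The series", "measured", "known", "first", "only" and "open" are said of these compounds alone.

The study compares three measured compounds and one that still awaits measurement. Compound 1 `Fc1cccc(F)c1C#Cc1cnc2ccccc2c1` and compound 2 `Fc1cccc(F)c1C#Cc1ccnc2ccccc12` are built from the same atoms joined differently; the difference between the two cores is not broken down here. In a functional assay on LS174T cells (Homo sapiens) for inhibition, with a stated time of 4 days, tested at 1 uM (a lower number here means a weaker effect, a higher number a stronger effect of the compound at the concentration tested), compound 1 gives 41.7%, whereas compound 2 gives 15.4%, the lowest of the three numbers and beyond the scatter from both others. Compound 3 `Fc1cccc(F)c1C#Cc1cnc2ccccc2c1Cl` gives 51.5% in this assay and carries the change (chloro in place of hydrogen on an aromatic carbon), and the step it produced is a number 9.8 percentage points higher from compound 1 to compound 3 (within the scatter). Compound 4 `Fc1cccc(F)c1C#Cc1ccnc2cc(Cl)ccc12` carries the change (chloro in place of hydrogen on an aromatic carbon). This is the same kind of change, not the same: in compound 3 the chloro sits on a six-membered aromatic ring with 1 nitrogen, ortho to a fused ring, ortho to a large group, meta to a fused ring and opposite the ring nitrogen, while in compound 4 it sits on a six-membered aromatic ring of carbon only, meta to a fused ring and para to a fused ring. In this assay, among the compounds with values here, the step is expected to be a number 7.6 percentage points higher from compound 2 to compound 4 (within the scatter), resting on the single earlier step of a number 9.8 percentage points higher from compound 1 to compound 3 (within the scatter) and on the low starting point of compound 2 at 15.4%. Compound 4 is therefore estimated at 23%, between 8% and 40%.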

Compound 4, a percentage reported as inhibition, at one concentration (the size of the read-out at that concentration, not a potency): 36%
Compound 4: middle estimate off by 13 percentage points, on the low side; low and high end bracket the measured number.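

On the core of compound 2, chloro in place of hydrogen on an aromatic carbon gives in this assay a number 20.6 percentage points higher from compound 2 to compound 4 (beyond the scatter) and so stands clear of the scatter, which the earlier step on the core of compound 1 did not. Set side by side, however, the two steps cannot be told apart: the same change on two cores in this assay, a number 9.8 percentage points higher (within the scatter) from compound 1 to compound 3 and a number 20.6 percentage points higher (beyond the scatter) from compound 2 to compound 4, 10.8 percentage points apart, within the scatter of two such steps. Within the data shown here, the change thus points the same way on both cores, but with only one pair per core and the chloro on a different kind of ring in each, this does not show whether the core or the place of the chloro shapes the size of the step, nor that the change would carry to a further core.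

The compounds shown leave open how a group other than chloro, such as a methoxy or an amine, would behave on the same aromatic carbon of either core. Also open, as far as these compounds go, is whether chloro on the other ring of each core would give a step of like size.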